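The compounds below may be only part of what the source reports. "The series", "measured", "known", "first", "only" and "open" are said of these compounds alone.

Measured so far in a functional assay on HCT-116 cells (Homo sapiens) for inhibition, read by luminescence, with a stated time of 72 h; a higher number here means a weaker inhibitor, a lower number a stronger inhibitor
compound 1 `Nc1ncnc2c1nc(Sc1cc3c(cc1Br)OCC3)n2CCC1CCN(C=O)CC1` gives 1200 nM
compound 2 `Nc1ncnc2c1nc(Sc1cc3occc3cc1Br)n2CCC1CCN(C=O)CC1` gives 260 nM
compound 3 `Nc1ncnc2c1nc(Sc1cc3c(cc1Br)OCCO3)n2CCC1CCN(C=O)CC1` gives 670 nM

Compound 3 at 670 nM lies within the scatter of compound 1 at 1200 nM and stands higher, beyond the scatter, than compound 2 at 260 nM on the numbers.

Compound 4 `C[C@@H](O)C(=O)N1CCC(CCn2c(Sc3cc4c(cc3Br)OCCO4)nc3c(N)ncnc32)CC1` keeps the sulfur-linked group of compound 3 and differs by 1-hydroxyethyl in place of hydrogen on a carbonyl carbon in words, 1-hydroxyethyl in place of hydrogen on a carbonyl carbon, so that formyl becomes (1-hydroxyethyl)carbonyl. Among the measured compounds shown here, no measured compound carries anything but hydrogen on that carbonyl carbon, so no measured step bears on this change directly. For the measured compounds named here, the only step available is a 4.6-fold lower number from compound 1 to compound 2 (0.66 log units; beyond the scatter) and it concerns a group on a sulfur, not the carbonyl carbon. Its size shows how far one change has moved the number in this assay within this small set, so it informs the width of the range and gives no direction.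

With compound 3 at 670 nM as the starting point, no shift beyond the scatter is expected. The estimated step is a 1.2-fold lower number from compound 3 to compound 4 (0.09 log units; within the scatter) and it is expected to stay within the scatter. For compound 4 the expected value is 550 nM with an estimated range from 170 nM to 1700 nM as the working figure.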

Compound 4, half-maximal inhibitory concentration: 920 nM
Compound 4: middle estimate off by 1.7-fold (0.22 log units), on the low side, within the range that was stated.
By their numbers in this assay, from the lowest: compound 2; then compounds 3, 4 and 1 (each within the scatter of the next).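

In this assay, among the compounds shown here, the only reading at the carbonyl carbon bound to the amide-type nitrogen in a ring is a 1.4-fold higher number from compound 3 to compound 4 (0.14 log units; within the scatter) for 1-hydroxyethyl in place of hydrogen, so this position accepts that group, with its defined stereocentre, without a shift that can be told from the scatter. For the compounds shown here, in this small set, the one step beyond the scatter remains a 4.6-fold lower number from compound 1 to compound 2 (0.66 log units; beyond the scatter) on the sulfur, while the first step at the carbonyl carbon stays within it, though a single pair says little about the position as a whole. No supporting data explain this reading.

Open at this carbonyl carbon is whether an aminomethyl group, a carboxylic acid or a longer chain would stay within the scatter of formyl, and whether the opposite configuration at the stereocentre of 1-hydroxyethyl would read the same. Also open, on these data alone, is whether (1-hydroxyethyl)carbonyl would give a similar step when paired with the sulfur-linked group of compound 2, which carries only formyl here.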